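The source may hold more compounds than are shown below. What is called first, only, known or untested is meant among the compounds shown, and "the series" means these compounds.

Compound 1 `O=S(=O)(NCCCNc1nccc(-c2c(-c3cccc(F)c3)nc3sccn23)n1)c1ccc(Br)cc1` gives 7040 nM in a functional assay on A-375 cells (Homo sapiens) for cytotoxicity, read by MTT assay; on this read-out higher numbers stand for weaker inhibition and lower numbers for stronger inhibition. Compound 2 `Cc1ccc(S(=O)(=O)NCCCNc2nccc(-c3c(-c4cccc(F)c4)nc4sccn34)n2)cc1` gives 8380 nM in this assay.

On these two numbers compound 2 stands highest, with compound 1 nearest; the step of a 1.2-fold higher number from compound 1 to compound 2 (0.08 log units; within the scatter) lies within the scatter. Compound 3 `O=C(NCCNc1nccc(-c2c(-c3cccc(F)c3)nc3sccn23)n1)c1ccccc1` differs from compound 2 by benzamido in place of (((4-methylphenyl)sulfonyl)amino)methyl on a saturated chain carbon, two bonds along the chain from a nitrogen on an aromatic ring. Within the data shown here, no measured step touches this part of the molecule, so the one step known, a swap on the distal ring, offers no guide to the size of this assay here. Compound 3 is therefore expected to stay near compound 2, with an estimated step of a 1.0-fold lower number from compound 2 to compound 3 (0.02 log units; within the scatter) and a wide range. The estimate for compound 3 is 8000 nM, between 2500 nM and 25000 nM.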

Compound 3, half-maximal inhibitory concentration: 5060 nM
Compound 3: middle estimate off by 1.6-fold (0.20 log units), on the high side; low and high end bracket the measured number.
By their numbers in this assay, from the lowest: compounds 3, 1 and 2 (each within the scatter of the next).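

In this assay, benzamido in place of (((4-methylphenyl)sulfonyl)amino)methyl on a saturated chain carbon, two bonds along the chain from a nitrogen on an aromatic ring, gives (a 1.7-fold lower number from compound 2 to compound 3 (0.22 log units; within the scatter)), and in place of (((4-bromophenyl)sulfonyl)amino)methyl it gives (a 1.4-fold lower number from compound 1 to compound 3 (0.14 log units; within the scatter)). This position therefore accepts an exchange of the whole sulfonyl-bearing group for benzamido with both steps staying within the scatter. No evidence at hand accounts for this result. As far as these compounds go, whether an amine, a carboxylic acid or a longer chain at this position would move the number beyond the scatter stays open.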